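The compounds below may be only part of what the source reports. "The series", "measured", "known", "first", "only" and "open" are said of these compounds alone.

Compound 2 `CN1[C@@H]2c3[nH]c4ccccc4c3C[C@H]1[C@H](C#N)N1[C@@H](CNC(=O)c3cc4ccccc4[nH]3)c3[nH]c4ccccc4c3C[C@@H]21` and compound 1 `CN1[C@@H]2c3[nH]c4ccccc4c3C[C@H]1[C@H](C#N)N1[C@@H](CNC(=O)c3ccc(Cl)cc3)c3[nH]c4ccccc4c3C[C@@H]21` share one core and differ only in the group on the carbonyl carbon of the amide. In a functional assay on HCT-116 cells (Homo sapiens) for cytotoxicity, read by MTT assay, with a stated time of 72 h (a lower number here means a stronger inhibitor, a higher number a weaker inhibitor), compound 1 gives 630 nM, and compound 2 gives 880 nM. The step of a 1.4-fold higher number from compound 1 to compound 2 (0.15 log units; within the scatter) is within the scatter, so compound 2 sits alongside compound 1 with no separation between the two that the assay can resolve.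

Compound 3 `CN1[C@@H]2c3[nH]c4ccccc4c3C[C@H]1[C@H](C#N)N1[C@@H](CNC(=O)/C=C/c3ccccc3)c3[nH]c4ccccc4c3C[C@@H]21` carries the change (2-phenylethenyl in place of 1H-indol-2-yl on a carbonyl carbon). Within the data shown here, the only measured step that bears on it is the exchange of one aryl group for another on the same carbonyl carbon, a 1.4-fold higher number from compound 1 to compound 2 (0.15 log units; within the scatter), which stayed within the scatter. A second exchange at the same place, to 2-phenylethenyl, therefore gives no ground to expect a shift beyond the scatter in this assay, in either direction. The expected step of a 1.1-fold lower number from compound 2 to compound 3 (0.04 log units; within the scatter) is accordingly small. In this assay compound 3 is estimated at 800 nM, with a range from 300 nM to 2500 nM, resting on compound 2 at 880 nM and compound 1 at 630 nM.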

Compound 3, half-maximal inhibitory concentration: 1960 nM
The estimate for compound 3 lay 2.5-fold (0.39 log units) below the measured number; the range from low to high includes it.
By their numbers in this assay, from the lowest: compounds 1 and 2 (each within the scatter of the next); then compound 3.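

Moving to 2-phenylethenyl on the carbonyl carbon gives the first difference at this position that this assay can resolve: the change produces a 2.2-fold higher number from compound 2 to compound 3 (0.35 log units; beyond the scatter) and, set against the other aromatic group, a 3.1-fold higher number from compound 1 to compound 3 (0.49 log units; beyond the scatter) with both steps modest but beyond the scatter. The position is thus not indifferent to what it carries, even though the exchange of 4-chlorophenyl for 1H-indol-2-yl gave no separation, and among these three compounds only compound 3, the one with a double bond outside aromatic rings, stands apart from the others. Nothing in the information available accounts for this loss of activity or ties it to any property of the group.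

From the compounds shown here alone, whether the double bond itself matters remains open, and a saturated 2-phenylethyl group or an unsubstituted phenyl on the same carbonyl carbon would be needed to decide it. Also open, going by these compounds, is how the position would respond to a group of a different kind, such as an aliphatic amine, a carboxylic acid or a longer carbon chain in place of these aromatic groups.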